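A few compounds are considered here, and "the series" means these few. Any claim that something is new, unique, unknown or untested is made for them only; others in the source may bear on it.

In a functional assay on HepG2 cells (Homo sapiens) for cytotoxicity, read by MTT assay, with a stated time of 48 h (a higher number here means a weaker inhibitor, a lower number a stronger inhibitor), compound 1 `CC1=NN(C(=O)c2ccc(C)cc2)C(c2ccccc2O)C1` gives 11300 nM and compound 3 `CCN(CC)CC(=O)N1N=C(C)CC1c1ccccc1O` gives 51600 nM, the higher of the two numbers available. Compound 2 `CC1=NN(C(=O)COc2ccc(Cl)cc2)C(c2ccccc2O)C1` is recorded as "not active" (no number reported), with no number to place it. Going by the values given here, the only measured step, a 4.6-fold higher number from compound 1 to compound 3 (0.66 log units; beyond the scatter), is modest but beyond the scatter; it puts (diethylamino)methyl in place of 4-methylphenyl on a carbonyl carbon.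

Compound 4 `CC1=NN(C(=O)CN2CCCCC2)C(c2ccccc2O)C1` keeps the core of compound 3 and carries piperidin-1-yl in place of diethylamino on a saturated chain carbon bound to a carbonyl carbon. Among the compounds with values here, no measured pair makes this exchange, so the step to compound 3 bears on it only loosely. That step replaced 4-methylphenyl, a much larger change of group than the one here, and it stayed modest. No shift beyond the scatter is therefore expected in this assay. The expected change is a 1.1-fold lower number from compound 3 to compound 4 (0.06 log units; within the scatter), with no firm direction. For compound 4 the estimated value is 45000 nM, with an expected range from 18000 nM to 110000 nM.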

Compound 4, half-maximal inhibitory concentration: 3020 nM
For compound 4 the middle estimate is 15-fold (1.17 log units) above the measured one; the measured number lies below the stated range.
By their numbers in this assay, from the lowest: compound 4; then compound 1; then compound 3.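

In this assay, going by these compounds alone, this position proves far more sensitive than the earlier compounds suggested: piperidin-1-yl in place of diethylamino, a small exchange on the saturated chain carbon bound to a carbonyl carbon, gives a 17-fold lower number from compound 3 to compound 4 (1.23 log units; beyond the scatter) and so is a larger step than replacing the whole 4-methylphenyl group. The amine-bearing side chain therefore does not go one way against 4-methylphenyl: a 4.6-fold higher number from compound 1 to compound 3 (0.66 log units; beyond the scatter) contrasts with a 3.7-fold lower number from compound 1 to compound 4 (0.57 log units; beyond the scatter), so the direction depends on which amine is carried. No measurement available here bears on what lies behind this difference.

Open, from the compounds shown here alone, is whether the shift belongs to piperidin-1-yl alone or extends to other cyclic amines, such as pyrrolidin-1-yl or morpholin-4-yl, on the same chain carbon. Also open, going by these compounds, is whether a longer chain between the carbonyl and the piperidine keeps the lower number.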